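Adding an Ester to the Piperidine Ring

A few compounds are considered here, and "the series" means these few. Any claim that something is new, unique, unknown or untested is made for them only; others in the source may bear on it.

Of the compounds shown here, three sharing one core have been measured in an assay on isolated protein (Cavia porcellus) with Sigma non-opioid intracellular receptor 1 (Homo sapiens) as the target, read by radioligand binding; a higher number here means a weaker inhibitor, a lower number a stronger inhibitor. Compound 1 `O=c1cc(-c2ccccc2)oc2cccc(OCCCN3CCC(O)CC3)c12` gives 125 nM, compound 2 `O=c1cc(-c2ccccc2)oc2ccc(OCCCN3CCC(O)CC3)cc12` gives 130 nM, and compound 3 `O=c1cc(-c2ccccc2)oc2ccc(OCCCCCCN3CCCCC3)cc12` gives 101 nM, the lowest of the three numbers, though each gap to the other two lies within the scatter. Within the data shown here, the only single-point step, a 1.3-fold lower number from compound 2 to compound 3 (0.11 log units; within the scatter), concerns the amine end of the chain and stays within the scatter. Compound 4 `CCOC(=O)C1CCN(CCCCCCOc2ccc3oc(-c4ccccc4)cc(=O)c3c2)CC1` differs from compound 3 by ethoxycarbonyl in place of hydrogen on a saturated ring carbon. Among the measured compounds shown here, no measured step tests an ester on this ring, so the change is expected to stay within the scatter, giving a 1.3-fold higher number from compound 3 to compound 4 (0.11 log units; within the scatter). Compound 4 is therefore estimated at 130 nM, with a range from 50 nM to 350 nM.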

Compound 4, half-maximal inhibitory concentration: 164 nM
The estimate for compound 4 lay 1.3-fold (0.10 log units) below the measured number; measured number inside the range.
By their numbers in this assay, from the lowest: compounds 3, 1, 2 and 4 (each within the scatter of the next).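

In this assay, ethoxycarbonyl in place of hydrogen on the saturated ring carbon, three ring bonds from the ring nitrogen, gives a 1.6-fold higher number from compound 3 to compound 4 (0.21 log units; within the scatter) and so shows that this carbon can carry a group of 5 heavy atoms without a step beyond the scatter. Nothing measured here explains this result. As far as these compounds go, whether a carboxylic acid or an amine at this ring carbon would also stay within the scatter remains open. So does whether the ethyl ester behaves the same way on a shorter chain.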